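Replacing 6-oxopiperidin-2-yl with pyridazin-3-yl on a carbonyl carbon

A few compounds are considered here, and "the series" means these few. Any claim that something is new, unique, unknown or untested is made for them only; others in the source may bear on it.

For the measured compounds named here, in a physicochemical assay for solubility, measured as kinetic solubility, with a stated time of 1 h, at pH 7.4 (on this read-out lower numbers stand for lower solubility and higher numbers for higher solubility), compound 2 `O=C1CCCC(C(=O)NC2=NN(c3ccc(Cl)c(Cl)c3)CC2)N1` gives 416000 nM, the only actual number so far. Compound 1 `Cn1ncc([N+](=O)[O-])c1C(=O)Nc1nc(-c2ccc(Cl)c(Cl)c2)cs1` reads < 1000 nM, which is a limit of the assay and not a number. Compound 3 `O=C(NC1=NN(c2ccc(Cl)c(Cl)c2)CC1)c1cccnn1` carries pyridazin-3-yl in place of 6-oxopiperidin-2-yl on a carbonyl carbon. Going by the values given here, no measured pair shows this change, so any expectation for it remains loose. Starting from compound 2 at 416000 nM, a fall in this assay beyond the usual scatter is expected, though a wide margin has to stay open. The expected size of that fall is given by the estimated 8.3-fold lower number from compound 2 to compound 3 (0.92 log units; beyond the scatter). For compound 3 the estimated value is 50000 nM, with an expected range from 8000 nM to 250000 nM.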

Compound 3, solubility: 67000 nM
For compound 3 the middle estimate is 1.3-fold (0.13 log units) below the measured one; the measured number falls inside the stated range.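

For the compounds shown here, at the carbonyl carbon whose other neighbour is an amide-type nitrogen, the first step in this assay is a 6.2-fold lower number from compound 2 to compound 3 (0.79 log units; beyond the scatter), so this position does respond to the exchange of 6-oxopiperidin-2-yl for pyridazin-3-yl. The change swaps a non-aromatic ring carrying a hydrogen-bond donor for an aromatic ring with no donor and more hydrogen-bond acceptors, and a single step cannot separate these differences. Nothing measured here gives a reason for the step.

On these data alone, it remains open whether the step follows the loss of the hydrogen-bond donor or the arrival of the aromatic ring. Also open, as far as these compounds go, is how a plain phenyl ring or a pyridin-2-yl group on the same carbonyl carbon would compare with pyridazin-3-yl.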